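A few compounds are considered here, and "the series" means these few. Any claim that something is new, unique, unknown or untested is made for them only; others in the source may bear on it.

In a functional assay on Maver1 cells (Homo sapiens) for inhibition, read by luminescence and CellTiter-Glo, with a stated time of 72 h; on this read-out higher numbers stand for weaker inhibition and lower numbers for stronger inhibition:
- Compound 1 `O=C(O)c1cc(-c2ccc(Oc3ccccc3)cc2)nn1C1CCCN(C(=O)CCl)C1`: 400 nM
- Compound 2 `C=CC(=O)N1CCCC(n2nc(-c3ccc(Oc4ccccc4)cc3)cc2C(=O)O)C1`: > 60000 nM

Going by the values given here, compound 1 holds the only exact number so far. The reading for compound 2, > 60000 nM, is a limit of the assay.

Compound 3 `CCOC(=O)c1cc(-c2ccc(Oc3ccccc3)cc2)nn1C1CCCN(C(=O)CCl)C1` turns the carboxy group of compound 1 into ethoxycarbonyl: ethyl in place of hydrogen on an oxygen next to a carbonyl group. Among the compounds with values here, the one measured step, an at least 150-fold higher number from compound 1 to compound 2 (2.17 log units; beyond the scatter), is large, but it swaps chloromethyl for vinyl on a carbonyl carbon. That is a different change, so it offers no size for this one. No shift beyond the scatter is therefore expected in this assay, and the expected step is a 1.3-fold lower number from compound 1 to compound 3 (0.12 log units; within the scatter). For compound 3 the estimate is 300 nM, with an expected range of 60 nM to 1500 nM.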

Compound 3, half-maximal inhibitory concentration: 1200 nM
Beside the measured number, compound 3's estimate is 4.0-fold (0.60 log units) below it; the range from low to high includes it.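

In this assay the change from carboxy to ethoxycarbonyl brings a 3.0-fold higher number from compound 1 to compound 3 (0.48 log units; beyond the scatter) and so shows that this position responds to change, though only modestly. Compound 3 still gives an exact value, so the hydrogen of the carboxy group is not essential for activity in this assay. Nothing in the data shown explains the shift. From the compounds shown here alone, whether the shift grows with the size of the group on this oxygen stays open. So does the effect of a methyl ester, or of a primary amide in place of the carboxylic acid.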